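Enone series: hydroxy replacing tert-butyl on the core

This account rests on a few compounds, and the source may have more. Where it says the series, first, only, none or still open, it means among the compounds named here.

Measured so far:
compound 1 `CC(=O)/C=C/c1cccc(F)c1O` — 51200 nM
compound 2 `CCOc1cccc(/C=C/C(C)=O)c1O` — 3310 nM
compound 3 `CC(=O)/C=C/c1cc(C(C)(C)C)ccc1O` — 8000 nM

In a functional assay for inhibition, with Oryctolagus cuniculus as the target (on this read-out lower numbers stand for stronger inhibition and higher numbers for weaker inhibition), compound 3 stands second highest of the three numbers; compound 2 is nearest, compound 1 furthest. Compound 4 `CC(=O)/C=C/c1cc(O)ccc1O` differs from compound 3 in one place: hydroxy in place of tert-butyl on an aromatic carbon. Within the data shown here, no measured step matches this change. Among the measured compounds shown here, the only measured step, a 15-fold lower number from compound 1 to compound 2 (1.19 log units; beyond the scatter), shows that a single change on the core can move this assay a long way, but it concerns another group at another place, so its direction carries no weight here. For the measured compounds named here, with no comparable step, the number for compound 4 is expected to stay near that of compound 3, a step of about a 1.3-fold higher number from compound 3 to compound 4 (0.10 log units; within the scatter) in this assay, with a wide range. Compound 4 is therefore estimated at 10000 nM, between 3000 nM and 40000 nM.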

Compound 4, half-maximal inhibitory concentration: 1430 nM
Estimate against measurement, compound 4: 7.0-fold (0.84 log units) above, outside the stated range (below it).
By their numbers in this assay, from the lowest: compound 4; then compound 2; then compound 3; then compound 1.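

In this assay, the position para to the hydroxy group and meta to the 2-acetylethenyl group responds to a change of substituent, with a 5.6-fold lower number from compound 3 to compound 4 (0.75 log units; beyond the scatter) on exchanging tert-butyl for hydroxy. The bulky tert-butyl group is therefore not required at this position for inhibition, and this step is the series' first reading there. No available evidence accounts for the shift.

From the compounds shown here alone, whether a methoxy group, an amine or a carboxylic acid at this position would follow hydroxy or tert-butyl remains open. Also open, going by these compounds, is whether the step carries over to cores bearing fluoro or ethoxy.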